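The compounds below may be only part of what the source reports. "The series", "measured", "known", "first", "only" and "open" are said of these compounds alone.

Working notes on the series.

Compound 2 `O=C(/C=C/c1cn([C@@H]2C[C@@H](C(=O)O)N(Cc3ccccc3)C2)nn1)NO` is the reference for this step. In an assay on Sf9 cells for inhibition of histone deacetylase 11 (Homo sapiens), read by fluorescence, tested at 0.5 uM (on this read-out lower numbers stand for less inhibition and higher numbers for more inhibition at the one concentration tested (going by the name of the read-out)), compound 2 gives 12%, the lowest of the two numbers in the set. Compound 3 `O=C(/C=C/c1cn([C@H]2C[C@@H](C(=O)O)N(CCCc3ccccc3)C2)nn1)NO` gives 29% in this assay, which is beyond the scatter above compound 2; compound 3 differs from compound 2 in more than one place, so the two values are only noted side by side. Compound 1 `O=C(NO)c1ccc(-c2cn([C@@H]3C[C@@H](C(=O)O)N(Cc4ccccc4)C3)nn2)cc1` gives < 10% in this assay, a limit of the assay and not a number; the limit of < 10% in this assay, at which 1 of the 3 values shown sits, covers this value. Within the data shown here, the one single-point step on record is a number at least 2 percentage points higher from compound 1 to compound 2 (that floor lies within the scatter), and it concerns the hydroxycarbamoyl arm rather than the group on the saturated ring carbon.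

Compound 4 `O=C(/C=C/c1cn([C@@H]2C[C@@H](CO)N(Cc3ccccc3)C2)nn1)NO` carries the change (hydroxymethyl in place of carboxy on a saturated ring carbon). Among the measured compounds shown here, no measured step tells of this change; the hydroxymethyl is absent from the measured compounds. The step from compound 2 to compound 4 is therefore expected to stay within the scatter, with no direction claimed, and the expected step is a number 2 percentage points higher from compound 2 to compound 4 (within the scatter). Compound 4 is estimated at 14% in this assay, with a range from 5% to 30%, and the assay may return only a limit for compound 4.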

Compound 4, a percentage reported as inhibition, at one concentration (the size of the read-out at that concentration, not a potency): < 10%
Compound 4 ended at the assay's limit; the forecaster's own chance of this, stated with the estimate: 30%; middle value at least 4 percentage points away from the limit.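

Among these compounds, the exchange of carboxy for hydroxymethyl on the saturated ring carbon next to the ring nitrogen is the first change at this position with a readable step, and in this assay it gives a number at least 2 percentage points lower from compound 2 to compound 4 (that floor lies within the scatter). In this assay compound 4 gives < 10%, which is a limit of the assay and not a number. The step therefore has a floor and no measured size, and it neither shows that carboxy is needed at this position nor shows that hydroxymethyl can stand in for it, because the series reaches the bottom of this read-out at this point: the limit of < 10% in this assay, at which 2 of the 4 values shown sit.

Open, as far as these compounds go, is whether the same exchange would leave a readable step on a background that reads higher, such as compound 3 at 29%, which differs from compound 2 in more than one place, so that the longer chain on the ring nitrogen and the configuration at the ring carbon remain unseparated. Also open, from the compounds shown here alone, is how an amide, a methyl ester or an amine on this same ring carbon would read against carboxy and hydroxymethyl in this assay.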